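Changing the group on the sulfonyl sulfur

The source may hold more compounds than are shown below. What is called first, only, known or untested is meant among the compounds shown, and "the series" means these compounds.

Two compounds built on a shared core have numbers in a functional assay on K562 cells (Homo sapiens) for inhibition, read by trypan blue exclusion, with a stated time of 72 h (a higher number here means a weaker inhibitor, a lower number a stronger inhibitor), so far. Compound 1 (`Cn1c(=O)c(C(=O)Nc2ccc(F)cc2F)cc2cnc(Nc3ccc4[nH]ccc4c3)nc21`) gives 5000 nM in this test. Compound 2 (`Cn1c(=O)c(S(=O)(=O)Cc2ccc(F)cc2)cc2cnc(Nc3ccc4[nH]ccc4c3)nc21`) gives 30000 nM as the higher of the two numbers, which makes it the weaker inhibitor. The move between them, (4-fluorobenzyl)sulfonyl in place of (2,4-difluorophenyl)carbamoyl on an aromatic carbon, is a 6.0-fold higher number from compound 1 to compound 2 (0.78 log units; beyond the scatter) and counts as a modest step.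

Compound 3 (`COc1ccc(S(=O)(=O)c2cc3cnc(Nc4ccc5[nH]ccc5c4)nc3n(C)c2=O)cc1`) has not yet been measured. It differs from compound 2 by 4-methoxyphenyl in place of 4-fluorobenzyl on a sulfonyl sulfur and so carries 4-methoxyphenyl in place of 4-fluorobenzyl on a sulfonyl sulfur. Going by the values given here, no measured step changes the group on that sulfur, so the one available step offers only a rough guide to size. Compound 1 at 5000 nM shows that this core can reach lower numbers, and compound 2 lies at the top of the measured span. A modest move toward a lower number is therefore expected, with an estimated size of a 2.5-fold lower number from compound 2 to compound 3 (0.40 log units; beyond the scatter) as the working figure. Compound 3 is expected at 12000 nM (2500 nM to 40000 nM).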

Compound 3, half-maximal inhibitory concentration: 300 nM
Compound 3: middle estimate off by 40-fold (1.60 log units), on the high side; the whole stated range lies above it.
By their numbers in this assay, from the lowest: compound 3; then compound 1; then compound 2.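

In this assay, going by these compounds alone, the group on the sulfonyl sulfur turns out to matter far more than the one earlier step suggested: 4-methoxyphenyl in place of 4-fluorobenzyl gives a 100-fold lower number from compound 2 to compound 3 (2.00 log units; beyond the scatter) with the rest of the molecule unchanged. The high number of compound 2 is therefore not a fixed price of carrying a sulfonyl group on that aromatic carbon, since (4-methoxyphenyl)sulfonyl in place of (2,4-difluorophenyl)carbamoyl gives a 17-fold lower number from compound 1 to compound 3 (1.22 log units; beyond the scatter) and so reverses the order that compound 1 and compound 2 had set, with compound 2 remaining the sulfonyl example that lies above compound 1. Nothing available on these compounds accounts for the size of this change.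

The step from compound 2 to compound 3 exchanges benzyl for phenyl and fluorine for methoxy together, so the compounds shown leave open which of the two carries the gain. Going by these compounds, a 4-fluorophenyl or a 4-methoxybenzyl group on the same sulfur would separate them, and whether a 4-aminophenyl group there would hold the low number also remains open.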